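Swapping methyl for chloro on compound 2

This account rests on a few compounds, and the source may have more. Where it says the series, first, only, none or still open, it means among the compounds named here.

For the measured compounds named here, in a functional assay on the whole organism (Hindlimb, strain albino) with Mus musculus as the target, in the maximal electroshock model, with a stated time of 0.5 h (on this read-out higher numbers stand for an effect only at larger amounts of compound and lower numbers for an effect already at smaller amounts), compound 2 `CC(=O)N1N=C(Nc2nc3ccc(C)cc3s2)CC1c1ccc(O)cc1` gives 50.2 umol/kg, at the low end of the three numbers known. Compound 3 `COc1ccc(C2CC(Nc3nc4ccc(C)cc4s3)=NN2C(C)=O)cc1O` gives 73.9 umol/kg. The gap is a 1.5-fold higher number from compound 2 to compound 3 (0.17 log units; within the scatter), so these two sit level. Compound 1 `COc1ccc(C2CC(Nc3nc4ccc(Cl)cc4s3)=NN2C(C)=O)cc1O` gives 127 umol/kg, beyond the scatter from compound 2. Compound 4 `CC(=O)N1N=C(Nc2nc3ccc(Cl)cc3s2)CC1c1ccc(O)cc1` differs from compound 2 by one change: chloro in place of methyl on an aromatic carbon. The closest evidence is the same swap in reverse, a 1.7-fold lower number from compound 1 to compound 3 (0.24 log units; within the scatter), which is within the scatter. Read the other way, this suggests a small move toward a higher number in this assay, probably no larger than the scatter. The expected change is a 1.7-fold higher number from compound 2 to compound 4 (0.23 log units; within the scatter). Compound 4 is estimated at 86 umol/kg, with an expected range of 45 umol/kg to 165 umol/kg.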

Compound 4, dose for half-maximal effect: 106 umol/kg
The estimate for compound 4 lay 1.2-fold (0.09 log units) below the measured number, within the range that was stated.
By their numbers in this assay, from the lowest: compounds 2, 3, 4 and 1 (each within the scatter of the next, the first and the last beyond it).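

In this assay, going from methyl to chloro gives a 2.1-fold higher number from compound 2 to compound 4 (0.32 log units; beyond the scatter), so on this core the swap clears the scatter, which the same swap between compound 1 and compound 3 did not. The swap points the same way on both cores, and the two sizes agree: the same change on two cores in this assay, a 1.7-fold lower number (0.24 log units; within the scatter) from compound 1 to compound 3 and a 2.1-fold lower number (0.32 log units; beyond the scatter) from compound 4 to compound 2, 1.2-fold (0.09 log units) apart, within the scatter of two such steps. With chloro in place, the change of the aryl group remains small, with a 1.2-fold lower number from compound 1 to compound 4 (0.08 log units; within the scatter).

Only methyl and chloro are compared at this position. On these data alone, whether a methoxy group, an amine or a bare hydrogen there would give a number as low as that of compound 2 remains open.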